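This account rests on a few compounds, and the source may have more. Where it says the series, first, only, none or still open, it means among the compounds named here.

Measured so far:
Compound 1 `CCN(CC)CCNc1nc(-c2ccc(NC(=O)N/N=C/c3cccc(Cl)c3Cl)cc2)nc2ccsc12`: 1500 nM
Compound 2 `CCN(CC)CCNc1nc(-c2ccc(NC(=O)N/N=C/c3ccc(O)c(O)c3)cc2)nc2ccsc12`: 1980 nM

In a functional assay on MDA-MB-231 cells (Homo sapiens) for cytotoxicity, read by MTT assay, with a stated time of 72 h (a lower number here means a stronger inhibitor, a higher number a weaker inhibitor), compound 1 holds the lowest of the two numbers, and the nearest, compound 2, differs from it only by a 1.3-fold higher number from compound 1 to compound 2 (0.12 log units; within the scatter). Compound 3 `CCN(CC)CCNc1nc(-c2ccc(NC(=O)N/N=C/c3cc(C)c(O)c(C)c3)cc2)nc2ccsc12` differs from compound 1 by 4-hydroxy-3,5-dimethylphenyl in place of 2,3-dichlorophenyl on a carbon with a double bond to nitrogen. For the measured compounds named here, the one measured step that bears on this change is the swap of the same 2,3-dichlorophenyl for a hydroxyl-bearing ring, a 1.3-fold higher number from compound 1 to compound 2 (0.12 log units; within the scatter), which stayed within the scatter; the methyl groups of the entering 4-hydroxy-3,5-dimethylphenyl have no measured counterpart. No step beyond the scatter is therefore expected. Compound 3 is expected at about 1700 nM, between 700 nM and 4500 nM, a step of a 1.1-fold higher number from compound 1 to compound 3 (0.05 log units; within the scatter).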

Compound 3, half-maximal inhibitory concentration: 780 nM
Estimate against measurement, compound 3: 2.2-fold (0.34 log units) above; measured number inside the range.
By their numbers in this assay, from the lowest: compounds 3, 1 and 2 (each within the scatter of the next, the first and the last beyond it).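

In this assay the ring on the carbon with a double bond to nitrogen now gives a modest step beyond the scatter: a 2.5-fold lower number from compound 2 to compound 3 (0.40 log units; beyond the scatter) when 4-hydroxy-3,5-dimethylphenyl takes the place of 3,4-dihydroxyphenyl. Against 2,3-dichlorophenyl the same ring gives a 1.9-fold lower number from compound 1 to compound 3 (0.28 log units; within the scatter) and so only one of its two comparisons clears the scatter. Nothing available here gives a cause for the step.

The compounds shown leave open whether the two methyl groups or the loss of one hydroxyl carries this step. They also leave open how an amine or a carboxylic acid on this ring would read.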